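Phenoxy to methoxy in a sulfonamide series

The source may report more compounds than this note shows. Statements on the series, on what has been measured and on what is new or still open speak of the compounds shown alone.

Measured in a functional assay on HT-29 cells (Homo sapiens) for antiproliferative activity, read by sulforhodamine B assay, with a stated time of 48 h; a higher number here means a weaker inhibitor, a lower number a stronger inhibitor:
compound 1 `CCc1ccccc1NS(=O)(=O)c1ccc(N2CCNC2=O)cc1`: 240 nM
compound 2 `O=C1NCCN1c1ccc(S(=O)(=O)Nc2ccc(Br)cc2)cc1`: 300 nM
compound 3 `O=C1NCCN1c1ccc(S(=O)(=O)Nc2cccc(Oc3ccccc3)c2)cc1`: 200 nM

Going by the values given here, compound 3, at 200 nM, lies within the scatter of both compound 1 and compound 2, so these three values set no order among the compounds. The next compound to read is compound 4 `COc1cccc(NS(=O)(=O)c2ccc(N3CCNC3=O)cc2)c1`, which carries methoxy where compound 3 carries phenoxy: methyl in place of phenyl on an oxygen on an aromatic ring. Among the compounds with values here, no measured step covers this exchange. Within the data shown here, the only measured step between compound 1 and compound 2, a 1.3-fold higher number from compound 1 to compound 2 (0.10 log units; within the scatter), concerns the group on a sulfonamide nitrogen as a whole and stays within the scatter, so it bears on the change only indirectly. With that evidence, no step beyond the scatter is expected in this assay, and the data give no firm direction. The estimated step is a 1.3-fold higher number from compound 3 to compound 4 (0.10 log units; within the scatter), which places the expected value among those of the measured compounds. For compound 4 the estimate is 250 nM, with an expected range of 110 nM to 570 nM.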

Compound 4, half-maximal inhibitory concentration: 120 nM
For compound 4 the middle estimate is 2.1-fold (0.32 log units) above the measured one; the measured number falls inside the stated range.
By their numbers in this assay, from the lowest: compounds 4, 3, 1 and 2 (each within the scatter of the next, the first and the last beyond it).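

In this assay the exchange of phenoxy for methoxy gives a 1.7-fold lower number from compound 3 to compound 4 (0.22 log units; within the scatter) and stays within the scatter, so the phenyl on this oxygen is not required to keep the value in this range. Going by these compounds alone, in place of 4-bromophenyl on a sulfonamide nitrogen, 3-methoxyphenyl gives a 2.5-fold lower number from compound 2 to compound 4 (0.40 log units; beyond the scatter) and is the first step beyond the scatter, though only a modest one, while in place of 2-ethylphenyl it gives a 2.0-fold lower number from compound 1 to compound 4 (0.30 log units; within the scatter) and stays within the scatter. No supporting measurement accounts for any of these steps.

Open, from the compounds shown here alone, is how far this oxygen tolerates other groups, such as a hydroxyl or a longer chain like ethoxy or benzyloxy. Also open, going by these compounds, is whether an amine or a carboxylic acid on the same ring would hold the value in this assay.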